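Adding a Second Propylamino Group to Compound 1

A few compounds are considered here, and "the series" means these few. Any claim that something is new, unique, unknown or untested is made for them only; others in the source may bear on it.

Compound 1 `CCCNc1ncnc2c1cnn2-c1ccccc1` stands among three close relatives that share one core. In a functional assay on G-361 cells (Homo sapiens) for cytotoxicity, read by sulforhodamine B assay (a higher number here means a weaker inhibitor of growth, a lower number a stronger inhibitor of growth), compound 1 gives > 100000 nM, which is a limit of the assay rather than a number. Compound 2 `Cc1nc(Nc2ccccc2)c2cnn(-c3ccccc3)c2n1` gives in this assay > 100000 nM, again only a limit. Compound 3 `CCNc1nc(C)nc2c1cnn2-c1ccccc1` gives in this assay > 100000 nM, also a limit. For the measured compounds named here, the single step between measured neighbours, a step that the two limits leave unreadable from compound 2 to compound 3, therefore cannot be read, as the limit of > 100000 nM in this assay, at which 3 of the 3 values shown sit, shows. Compound 4 `CCCNc1nc(NCCC)c2cnn(-c3ccccc3)c2n1` differs from compound 1 by propylamino in place of hydrogen on an aromatic carbon. Going by the values given here, no measured step bears readably on this change, so the step that the limit leaves unreadable from compound 1 to compound 4 is expected to amount to none beyond the scatter. Compound 4 is accordingly estimated at 150000 nM, within 40000 nM to 500000 nM, and most probably reported only as a limit.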

Compound 4, concentration for total growth inhibition: > 100000 nM
Compound 4: no number, only a limit; the forecaster's own chance of this, stated with the estimate: 70%; the middle value lies beyond the limit too.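

The step from compound 1 to compound 4 cannot be read, because both values are limits rather than numbers: the limit of > 100000 nM in this assay, at which 4 of the 4 values shown sit. The compounds shown leave open how any change on the shared core would read in this assay as an actual number.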